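Compound 3 to compound 4: a larger aromatic group

This account rests on a few compounds, and the source may have more. Where it says the series, first, only, none or still open, it means among the compounds named here.

Measured in a functional assay on HeLa S3 cells (Homo sapiens) for antiproliferative activity, read by XTT assay, with a stated time of 72 h; a higher number here means a weaker inhibitor, a lower number a stronger inhibitor:
- compound 1 `CN(C)c1ncnc2c1c(-c1ccsc1)cn2[C@@H]1O[C@H](CO)[C@@H](O)[C@H]1O`: > 15000 nM, a limit
- compound 2 `COc1nc(N)nc2c1c(-c1ccccc1)cn2[C@@H]1O[C@H](CO)[C@@H](O)[C@H]1O`: > 20000 nM, a limit
- compound 3 `Nc1nc2c(c(-c3ccoc3)cn2[C@@H]2O[C@H](CO)[C@@H](O)[C@H]2O)c(=O)[nH]1`: 10700 nM

Going by the values given here, compound 3 gives the only actual number in this short set, while the two other results are limits. Compound 1 sits at its limit of > 15000 nM. Compound 2 sits at its limit of > 20000 nM.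

Compound 4 `Nc1nc2c(c(-c3cc4ccccc4o3)cn2[C@@H]2O[C@H](CO)[C@@H](O)[C@H]2O)c(=O)[nH]1` has 1-benzofuran-2-yl in place of furan-3-yl on an aromatic carbon of a five-membered aromatic ring with 1 nitrogen, part of a fused or bridged system of two rings. The counted change is 1-benzofuran-2-yl in place of furan-3-yl on an aromatic carbon.

Among the compounds with values here, no two measured compounds differ in one place, so no direct comparison sets the size of this step. Nothing in the measured set points to a large gain or loss, and the expectation starts from compound 3 at 10700 nM. In this assay, no change beyond the scatter is expected. The estimated step of a 1.4-fold higher number from compound 3 to compound 4 (0.15 log units; within the scatter) stays within the usual scatter. A limit instead of a number remains a real possibility for this measurement. The expected value for compound 4 is 15000 nM, with an estimated range of 5000 nM to 40000 nM.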

Compound 4, half-maximal inhibitory concentration: > 20000 nM
Compound 4 ended at the assay's limit (the forecaster's own chance of this, stated with the estimate: 50%); middle value at least 1.3-fold (0.12 log units) from the limit.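

In this assay, going by these compounds alone, putting 1-benzofuran-2-yl in place of furan-3-yl on an aromatic carbon gives the first comparison between compounds that differ in one place: an at least 1.8-fold higher number from compound 3 to compound 4 (0.27 log units; that floor lies within the scatter). The result for compound 4 is a limit and not a number: the limit of > 20000 nM in this assay, at which 2 of the 4 values shown sit. On these data alone, the larger group, which adds a six-membered aromatic ring of carbon only, brings no gain at this position, but the floor of the step lies within the scatter, so a real loss is not established and the full size of the step remains unknown.

Compounds 1 and 2 differ from compound 3 in more than one place, so their steps cannot be read. An aminomethyl group, a carboxylic acid or a longer alkyl chain on this aromatic carbon would test whether anything other than an aromatic ring can give a number clearly lower than that of compound 3 at 10700 nM.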